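A few compounds are considered here, and "the series" means these few. Any claim that something is new, unique, unknown or untested is made for them only; others in the source may bear on it.

Measured compounds:
- compound 1 `O=[N+]([O-])c1ccccc1CSc1nnc(-c2ccc3c(c2)OCCO3)n1-c1ccccc1`: 26500 nM
- compound 2 `O=[N+]([O-])c1ccc(CSc2nnc(-c3ccc4c(c3)OCCO4)n2-c2ccccc2)cc1`: 48600 nM
- compound 3 `Clc1cccc(CSc2nnc(-c3ccc4c(c3)OCCO4)n2-c2ccccc2)c1`: 51200 nM

The three compounds share one core and differ only in the group carried on a saturated chain carbon bound to a sulfur. In a functional assay on BGC-823 cells (Homo sapiens) for antiproliferative activity, read by MTT assay, with a stated time of 24 h (on this read-out higher numbers stand for weaker inhibition and lower numbers for stronger inhibition), compound 2 gives 48600 nM, a number that sits close to both of the others: the step of a 1.8-fold higher number from compound 1 to compound 2 (0.26 log units; within the scatter) and the step of a 1.1-fold higher number from compound 2 to compound 3 (0.02 log units; within the scatter) both stay within the scatter, and so does a 1.9-fold higher number from compound 1 to compound 3 (0.29 log units; within the scatter), so the three compounds cannot be told apart on these numbers.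

Compound 4 `Brc1ccc(CSc2nnc(-c3ccc4c(c3)OCCO4)n2-c2ccccc2)cc1` has not been measured. It differs from compound 2 in one place: bromo in place of nitro on an aromatic carbon. Among the measured compounds shown here, the steps that bear on this change are the three swaps of one group for another at the same place, and none of them moved the number beyond the scatter. By the same reasoning, no step beyond the scatter is expected from compound 2 to compound 4 in this assay: a 1.1-fold lower number from compound 2 to compound 4 (0.03 log units; within the scatter). Compound 4 is therefore estimated at 45000 nM, with a range from 18000 nM to 110000 nM.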

Compound 4, half-maximal inhibitory concentration: 33800 nM
For compound 4 the middle estimate is 1.3-fold (0.12 log units) above the measured one; measured number inside the range.
By their numbers in this assay, from the lowest: compounds 1, 4, 2 and 3 (each within the scatter of the next).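

In this assay, swapping nitro, with its three heavy atoms and two hydrogen-bond acceptors, for bromo, a single heavy atom with no acceptors, at this place para to a large group gives a 1.4-fold lower number from compound 2 to compound 4 (0.16 log units; within the scatter) and so does not move the number beyond the scatter. The 4-bromophenyl group also stays level with the two other groups compared at this chain carbon, as shown by a 1.5-fold lower number from compound 3 to compound 4 (0.18 log units; within the scatter) and by a 1.3-fold higher number from compound 1 to compound 4 (0.11 log units; within the scatter), which adds a fourth group that the assay cannot separate from the rest. No measurement here speaks to what lies behind these numbers.

Still open, going by these compounds, is whether an amine, a carboxylic acid or a longer chain in place of bromo would shift the number beyond the scatter. Also open, on these data alone, is whether the same swap of nitro for bromo would behave alike on a different core.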